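The compounds below may be only part of what the source reports. "The series", "measured", "known", "first", "only" and "open" are said of these compounds alone.

Measured in an ADME assay on L929 cells (Mus musculus) for cytotoxicity, read by resazurin assay, with a stated time of 72 h; on this read-out lower numbers stand for stronger inhibition and higher numbers for weaker inhibition:
Compound 1 `CCc1ccc(C(=O)/C=C/c2ccc3c(c2)B(O)OC3)cc1`: > 10 ug/mL
Compound 2 `Cn1cccc1C(=O)/C=C/c1ccc2c(c1)B(O)OC2`: > 10 ug/mL

Both entries are limits of the assay, not numbers. Compound 2 stands at > 10 ug/mL, which is a limit. Among the compounds with values here, the series so far comes down to one observation: the limit of > 10 ug/mL in this assay, at which 2 of the 2 values shown sit. Within the data shown here, no step between measured compounds can be read from this.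

Compound 3 `O=C(/C=C/c1ccc2c(c1)B(O)OC2)c1ccc(Cl)cc1` is still unmeasured. Its difference from compound 2 is 4-chlorophenyl in place of 1-methyl-1H-pyrrol-2-yl on a carbonyl carbon, with 4-chlorophenyl in place of 1-methyl-1H-pyrrol-2-yl on a carbonyl carbon. Compound 1 also has a six-membered aromatic ring of carbon only on that carbonyl carbon, and compound 1 gives > 10 ug/mL, also a limit. On that basis, no change beyond the scatter is expected in this assay, although a modest fall in the number remains possible. The expected size of the change is a step that the limit leaves unreadable from compound 2 to compound 3. The estimate for compound 3 is 12 ug/mL, with an expected range from 4 ug/mL to 30 ug/mL.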

Compound 3, half-maximal inhibitory concentration: > 10 ug/mL
Compound 3: only a limit was reported; the forecaster's own chance of this, stated with the estimate: 65%; the middle value is on the limit's open side.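

In this assay compound 3 gives only a limit, so no new step can be read from compound 3 to compound 1 or compound 2: the limit of > 10 ug/mL in this assay, at which 3 of the 3 values shown sit.

The compounds shown leave open how far any group on the carbonyl carbon moves this read-out.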